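Trading thiophen-2-yl for 4-(trifluoromethyl)phenyl

This account rests on a few compounds, and the source may have more. Where it says the series, first, only, none or still open, it means among the compounds named here.

Of the compounds shown here, three sharing one core have been measured in a functional assay on MOLT-4 cells (Homo sapiens) for antiproliferative activity (on this read-out lower numbers stand for stronger inhibition and higher numbers for weaker inhibition), so far. Compound 1 `COc1cc(C(=O)c2sc(-c3ccc(Br)cc3)cc2N)cc(OC)c1OC` carries 4-bromophenyl and gives 92 nM in this test. Compound 2 `COc1cc(C(=O)c2sc(-c3ccsc3)cc2N)cc(OC)c1OC` carries thiophen-3-yl and gives 8.8 nM in the same test. Compound 3 `COc1cc(C(=O)c2sc(-c3cccs3)cc2N)cc(OC)c1OC` carries thiophen-2-yl and gives 8.9 nM as its result, which places it level with compound 2 and far from compound 1, at the strong end of this small set.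

Compound 4 `COc1cc(C(=O)c2sc(-c3ccc(C(F)(F)F)cc3)cc2N)cc(OC)c1OC` has 4-(trifluoromethyl)phenyl in place of thiophen-2-yl on an aromatic carbon. For the measured compounds named here, two measured steps bear most directly on this swap, since each replaces a substituted phenyl with a five-membered ring: a 10-fold lower number from compound 1 to compound 3 (1.01 log units; beyond the scatter) and a 10-fold lower number from compound 1 to compound 2 (1.02 log units; beyond the scatter) are both large. Exchanging one thiophene attachment for the other matters little here, as a 1.0-fold higher number from compound 2 to compound 3 (0.00 log units; within the scatter) shows. Compound 4 makes the reverse kind of change, and compound 1 at 92 nM is its nearest model, although no measurement compares bromo with trifluoromethyl directly. The expected result in this assay is a large rise of similar size, estimated as an 11-fold higher number from compound 3 to compound 4 (1.05 log units; beyond the scatter) on this read-out. For compound 4 the estimate is 100 nM with an expected range from 30 nM to 330 nM for the coming measurement.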

Compound 4, half-maximal inhibitory concentration: 250 nM
Compound 4: the middle estimate sits 2.5-fold (0.40 log units) below what was measured; the range from low to high includes it.
By their numbers in this assay, from the lowest: compounds 2 and 3 (each within the scatter of the next); then compound 1; then compound 4.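

In this assay, the two substituted phenyl groups do not behave alike: a 2.7-fold higher number from compound 1 to compound 4 (0.43 log units; beyond the scatter) is a modest change, yet it lies beyond the scatter, so what the phenyl ring carries matters, and not only whether a phenyl ring or a thiophene sits at this position on the shared core. Measured against either thiophene, the cost of 4-(trifluoromethyl)phenyl is large, with a 28-fold higher number from compound 3 to compound 4 (1.45 log units; beyond the scatter) and a 28-fold higher number from compound 2 to compound 4 (1.45 log units; beyond the scatter), and this makes compound 4 the weakest of the four compounds in this test. No supporting evidence is available to explain why trifluoromethyl and bromo give different results here.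

The compounds shown leave open whether the weaker results come from the phenyl ring itself or from the groups it carries, and a plain phenyl group or a phenyl ring bearing a methoxy group or an amine would help separate the two. They also leave open whether the low numbers of compound 2 and compound 3 belong to thiophene alone or extend to another five-membered ring such as furan.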